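The source may report more compounds than this note shows. Statements on the series, on what has been measured and on what is new or still open speak of the compounds shown alone.

Compound 1 `CCN(CC)CCCOc1cc2ncnc(Nc3nc4ccc(C(=O)Nc5c(C)cccc5C)cc4s3)c2cc1OC` carries a dimethylphenyl amide; in a functional assay on A549 cells (Homo sapiens) for cytotoxicity, read by WST assay, with a stated time of 72 h (a lower number here means a stronger inhibitor, a higher number a weaker inhibitor), compound 1 reaches only the limit of > 100000 nM, which is a limit of the assay and not a number. Going by the values given here, compound 2 `CCN(CC)CCCOc1cc2ncnc(Nc3nc4ccc(C(=O)Nc5c(C)cccc5Cl)cc4s3)c2cc1OC` differs by a chloro in place of a methyl on an aromatic carbon, and in this assay compound 2 gives 10600 nM, the only number among the values shown. The step of an at least 9.4-fold lower number from compound 1 to compound 2 (0.97 log units; beyond the scatter) is measured only against the limit (the limit of > 100000 nM in this assay, at which 1 of the 2 values shown sits). Compound 3 `CCN(CC)CCCOc1cc2ncnc(Nc3nc4ccc(C(=O)Nc5c(C)cc(C)cc5C)cc4s3)c2cc1OC` is the next step: 2,4,6-trimethylphenyl in place of 2-chloro-6-methylphenyl on an amide-type nitrogen. This removes the very chloro whose arrival gave that step, so a move back toward the weaker side is expected, as a step of a 5.7-fold higher number from compound 2 to compound 3 (0.75 log units; beyond the scatter). For compound 3 an estimate of 60000 nM is expected in this assay, within 15000 nM to 200000 nM, with a real chance that only a limit is reported.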

Compound 3, half-maximal inhibitory concentration: 5700 nM
Compound 3: middle estimate off by 11-fold (1.02 log units), on the high side, outside the stated range (below it).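

In this assay the change to the 2,4,6-trimethylphenyl amide gives a 1.9-fold lower number from compound 2 to compound 3 (0.27 log units; within the scatter), so compound 3 carries no chloro and still cannot be told apart from compound 2; the chloro is thus not the only route to a measurable value on this amide-type nitrogen. Compound 3 differs from compound 1 by one added methyl on an aromatic carbon, and that single change gives an at least 17-fold lower number from compound 1 to compound 3 (1.24 log units; beyond the scatter). This step rests on compound 1, whose value is a limit and not a number: the limit of > 100000 nM in this assay, at which 1 of the 3 values shown sits.

The compounds shown leave open how a methoxy, a fluoro or a trifluoromethyl would read in the place of that added methyl. They also leave open what an amine or a carboxylic acid on this phenyl ring would give.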